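This account rests on a few compounds, and the source may have more. Where it says the series, first, only, none or still open, it means among the compounds named here.

Compound 1 `CC(C)n1ncc2c(C(=O)Nc3cccnc3)cc(-c3cccs3)nc21` carries an amide whose nitrogen bears a pyridin-3-yl group, and it has been tested in an ADME assay on LLC-MK2 cells (Macaca mulatta) for cytotoxicity, read by spectrophotometry and crystal violet staining, with a stated time of 4 days; on this read-out lower numbers stand for higher toxicity in this test and higher numbers for lower toxicity in this test. For compound 1 the result is a limit of the assay rather than a number, reported as > 200000 nM. Two related compounds differ only in small ways. Compound 2 `CC(C)n1ncc2c(C(=O)Nc3cccnc3)cc(-c3ccsc3)nc21` gives 37000 nM in this assay. Compound 3 `CC(C)n1ncc2c(C(=O)Nc3ncccn3)cc(-c3ccsc3)nc21` gives 50000 nM in this assay. The measured step of an at least 5.4-fold lower number from compound 1 to compound 2 (0.73 log units; beyond the scatter) concerns the thiophene and is beyond the scatter. The measured step of a 1.4-fold higher number from compound 2 to compound 3 (0.13 log units; within the scatter) concerns the group on the amide-type nitrogen and stays within the scatter.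

Compound 4 `CC(C)n1ncc2c(C(=O)Nc3cc(F)ccc3F)cc(-c3cccs3)nc21` differs from compound 1 by 2,5-difluorophenyl in place of pyridin-3-yl on an amide-type nitrogen. Among the measured compounds shown here, the one measured step at the same place, a 1.4-fold higher number from compound 2 to compound 3 (0.13 log units; within the scatter), was small, while the step of an at least 5.4-fold lower number from compound 1 to compound 2 (0.73 log units; beyond the scatter) touches a different part of the molecule and does not bear on this change. The expected step of a number no higher from compound 1 to compound 4 (the limit leaves the size open) is therefore none beyond the scatter. Compound 4 is estimated to give about 200000 nM in this assay, with a range from 80000 nM to 500000 nM. Because compound 1 sits at the limit (the limit of > 200000 nM in this assay, at which 1 of the 3 values shown sits), compound 4 is expected to return only a limit as well.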

Compound 4, half-maximal cytotoxic concentration: 100000 nM
Compound 4: middle estimate off by 2.0-fold (0.30 log units), on the high side; low and high end bracket the measured number.
By their numbers in this assay, from the lowest: compounds 2, 3 and 4 (each within the scatter of the next, the first and the last beyond it). At a limit, above all of these: compound 1.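

In this assay, the change on the amide-type nitrogen gives an at least 2.0-fold lower number from compound 1 to compound 4 (0.30 log units; that floor lies within the scatter). Until now this place had been compared only between pyridin-3-yl and pyrimidin-2-yl on a thiophen-3-yl compound, whereas here it is changed on a thiophen-2-yl compound, to a six-membered aromatic ring of carbon only that carries fluorine, and compound 4 returns a number rather than a limit. Compound 1 stands at a limit, so the real size of this step cannot be read, and it may be larger than its floor: the limit of > 200000 nM in this assay, at which 1 of the 4 values shown sits.

The compounds shown do not separate the effect of replacing the ring nitrogen from that of adding the two fluorines, which a plain phenyl or a phenyl with a single fluorine on the amide-type nitrogen could help to do. They also leave open whether 2,5-difluorophenyl would give a similar result on a thiophen-3-yl compound, or how an amine or a carboxylic acid on that ring would read in this assay.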